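The source may hold more compounds than are shown below. What is called first, only, known or untested is meant among the compounds shown, and "the series" means these compounds.

In a functional assay on HT-29 cells (Homo sapiens) for cytotoxicity, read by MTT assay, with a stated time of 72 h (a higher number here means a weaker inhibitor, a lower number a stronger inhibitor), two compounds built on a shared core have been measured so far. Compound 1 `Cn1c(=O)c(C(=O)Nc2ccc(Oc3ccncc3-c3cccnc3)c(F)c2)nn(-c2ccccc2F)c1=O` gives 2100 nM. Compound 2 `O=C(Nc1ccc(Oc2ccncc2-c2cccnc2)c(F)c1)c1ccnn(-c2ccc(Cl)cc2)c1=O`, which carries a 4-chlorophenyl on that core, gives 4560 nM, the higher of the two numbers; the gap to compound 1 lies beyond the scatter, so on the numbers shown compound 2 stands as the weaker inhibitor of the pair. Compound 3 `O=C(Nc1ccc(Oc2ccncc2-c2cccnc2)c(F)c1)c1ccnn(-c2ccc(F)cc2)c1=O` has not yet been measured in this assay. It differs from compound 2 in one place: fluoro in place of chloro on an aromatic carbon. Within the data shown here, no measured pair in this set differs in only this way, so there is no measured step to lean on. An exchange of one halogen for another at the same place, with no change in ring count, donors, acceptors or charge, is expected to move the number little, most likely by no more than the scatter, in either direction. For compound 3 the estimate is 5500 nM, within a range of 2500 nM to 12000 nM. This estimate amounts to an expected step of a 1.2-fold higher number from compound 2 to compound 3 (0.08 log units; within the scatter), expected to stay within the scatter.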

Compound 3, half-maximal inhibitory concentration: 4770 nM
Estimate against measurement, compound 3: 1.2-fold (0.06 log units) above; low and high end bracket the measured number.
By their numbers in this assay, from the lowest: compound 1; then compounds 2 and 3 (each within the scatter of the next).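

In this assay, among these compounds, the exchange of chloro for fluoro on an aromatic carbon, para to a large group, gives the first step that can be read at this position, since compound 1 and compound 2 differ in more than one place. Going from 4-chlorophenyl to 4-fluorophenyl gives (a 1.0-fold higher number from compound 2 to compound 3 (0.02 log units; within the scatter)), so on this core and in this assay the two halogens cannot be told apart at this place. No measurement at hand bears on the reason for this result.

This single step spans only two halogens, so it leaves open how the same place would read with an amine, a carboxylic acid, a methoxy group or a longer chain in place of the halogen. It also leaves open whether the same exchange of chloro for fluoro would read alike on the core of compound 1, and whether the place matters at all for activity in this assay once the group there is something other than a halogen.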